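The source may report more compounds than this note shows. Statements on the series, on what has been measured and on what is new or still open speak of the compounds shown alone.

Measured in a functional assay on MDA-MB-231 cells (Homo sapiens) for antiproliferative activity, read by MTT assay, with a stated time of 72 h; a lower number here means a stronger inhibitor, a higher number a weaker inhibitor:
- Compound 1 `O=C(CCc1cccc2c1B(O)OC2)Nc1nccs1`: > 100000 nM, a limit of the assay and not a number
- Compound 2 `C#Cc1ccc(NC(=O)CCc2cccc3c2B(O)OC3)cc1`: 6600 nM
- Compound 3 `CC(C)(C)c1ccc(NC(=O)CCc2cccc3c2B(O)OC3)cc1`: 33000 nM

Of the two compounds with true numbers, compound 3 stands higher, and so is the weaker inhibitor. Compound 4 `O=C(CCc1cccc2c1B(O)OC2)Nc1ccc([N+](=O)[O-])cc1` carries nitro in place of tert-butyl on an aromatic carbon, para to a large group: nitro in place of tert-butyl on an aromatic carbon. Within the data shown here, only one measured step changes this same place, a 5.0-fold higher number from compound 2 to compound 3 (0.70 log units; beyond the scatter), and it is modest. There, tert-butyl gave the higher number. Among the measured compounds shown here, a modest move toward a lower number is therefore expected in this assay, no larger than that step. The expected change is a 2.4-fold lower number from compound 3 to compound 4 (0.37 log units; beyond the scatter). For compound 4 the estimated value is 14000 nM, with an expected range of 5000 nM to 50000 nM.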

Compound 4, half-maximal inhibitory concentration: 36000 nM
The estimate for compound 4 lay 2.6-fold (0.41 log units) below the measured number; measured number inside the range.
By their numbers in this assay, from the lowest: compound 2; then compounds 3 and 4 (each within the scatter of the next). At a limit, above all of these: compound 1.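

Putting nitro in place of tert-butyl on this aromatic carbon leaves the number within the scatter (a 1.1-fold higher number from compound 3 to compound 4 (0.04 log units; within the scatter)), although the two groups differ in their atoms and in hydrogen-bond acceptors. Nitro also stands apart from ethynyl (a 5.5-fold higher number from compound 2 to compound 4 (0.74 log units; beyond the scatter)), so the gap seen earlier is not particular to tert-butyl: among these three compounds, only ethynyl gives the lower number. Nothing given here explains this ranking. Going by these compounds, whether an amine or a carboxylic acid at this same place would read like nitro or like ethynyl remains open.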